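A few compounds are considered here, and "the series" means these few. Any claim that something is new, unique, unknown or untested is made for them only; others in the source may bear on it.

Measured compounds:
- compound 1, `Cc1nc2sc(-c3ccccc3)nc2c(=O)[nH]1`: in an assay on CHO cells for displacement of a labelled ligand from adenosine receptor A1 (Homo sapiens), read by scintillation counting, with a stated time of 120 min, tested at 1 uM (on this read-out lower numbers stand for less inhibition and higher numbers for more inhibition at the one concentration tested (going by the name of the read-out)), compound 1 gives 11%
- compound 2, `Cc1nc2sc(-c3cccc(Cl)c3)nc2c(=O)[nH]1`: compound 2 gives 24%
- compound 3, `Cc1nc2sc(Nc3cccc(Cl)c3)nc2c(=O)[nH]1`: compound 3 gives 44%

Compound 1 and compound 2 share a core and differ in one place: chloro in place of hydrogen on an aromatic carbon. This change produced a number 13 percentage points higher from compound 1 to compound 2 (beyond the scatter). Compound 3 carries a different core; how its core differs from that of compound 1 is not broken down here. What the values show is that compound 3 stands highest of the three, with compound 2 the nearest and compound 1 the furthest from it.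

Compound 4, `Cc1nc2sc(Nc3ccc(Cl)c(Cl)c3)nc2c(=O)[nH]1`, has not yet been measured. It differs from compound 3 in one place: chloro in place of hydrogen on an aromatic carbon. Among the measured compounds shown here, this is the same kind of change as the one from compound 1 to compound 2, but not the same: in compound 2 the entering chloro sits meta to a large group, whereas in compound 4 it sits ortho to a chloro group and para to a large group. For the measured compounds named here, the expectation for compound 4 rests on compound 3 because of 44% and on the earlier step because of a number 13 percentage points higher from compound 1 to compound 2 (beyond the scatter), the only measured example of this kind of change. Beside that earlier step, the step is expected to be a number 10 percentage points higher from compound 3 to compound 4 (within the scatter). For compound 4 the estimate is 54%, with a range from 35% to 72%.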

Compound 4, a percentage reported as inhibition, at one concentration (the size of the read-out at that concentration, not a potency): 30%
Compound 4: the middle estimate sits 24 percentage points above what was measured; the measured number lies below the stated range.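

In this assay, chloro in place of hydrogen on an aromatic carbon gave a number 14 percentage points lower from compound 3 to compound 4 (beyond the scatter), so the rise seen on the core of compound 1 did not carry over to the core of compound 3: the same change on two cores in this assay, a number 13 percentage points higher (beyond the scatter) from compound 1 to compound 2 and a number 14 percentage points lower (beyond the scatter) from compound 3 to compound 4, 27 percentage points apart, beyond the scatter of two such steps

The comparison is not one of core alone: in compound 4 the entering chloro sits ortho to a chloro group and para to a large group, and the ring of compound 3 already carries a chloro, which the ring of compound 1 does not. With a single step on each core, the data show that this change cannot be assumed to keep its direction from one core to the other in this series, but they do not separate the part played by the core from the part played by the place on the ring, and they give no rule for any further core.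

Going by these compounds, it remains open whether a methoxy or a trifluoromethyl group on the same ring would follow the chloro steps on either core. Also open, on these data alone, is how these steps would behave with a longer chain in place of the methyl on the shared part of the cores, and how they would read as potencies rather than as inhibition at one concentration.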